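A Benzamide Arm Replaces the Pyrazole of Compound 3

The source may hold more compounds than are shown below. What is called first, only, known or untested is meant among the compounds shown, and "the series" means these compounds.

Three compounds sharing one core were measured in an assay on CHO cells for displacement of a labelled ligand from adenosine receptor A1 (Homo sapiens), read by scintillation counting, with a stated time of 90 min; on this read-out lower numbers stand for stronger inhibition and higher numbers for weaker inhibition. Compound 1 `N#Cc1c(N)nc(SCc2cccnc2)c(C#N)c1-c1ccc(OCC2CC2)cc1` gives 67 nM, compound 2 `CCOc1ccc(-c2c(C#N)c(N)nc(SCc3ccn[nH]3)c2C#N)cc1` gives 21 nM, and compound 3 `N#Cc1c(N)nc(SCc2ccn[nH]2)c(C#N)c1-c1ccc(OCC2CC2)cc1` gives 552 nM. Compound 3 therefore stands highest of the three, with compound 1 nearest and compound 2 furthest away. Two single changes lead to compound 3: an 8.2-fold higher number from compound 1 to compound 3 (0.92 log units; beyond the scatter), and a 26-fold higher number from compound 2 to compound 3 (1.42 log units; beyond the scatter).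

Compound 4 `N#Cc1c(N)nc(SCc2cccc(C(N)=O)c2)c(C#N)c1-c1ccc(OCC2CC2)cc1` departs from compound 3 at the same place as the first of those steps: 3-carbamoylphenyl in place of 1H-pyrazol-5-yl on a saturated chain carbon bound to a sulfur. Within the data shown here, only the step from compound 1 to compound 3 bears directly on this position, and it shows that a six-membered aromatic ring on that carbon went with a markedly lower number than the pyrazolyl group. The step from compound 2 to compound 3 concerns the other end of the molecule and does not speak to the change in compound 4. A step of roughly the size seen between compound 1 and compound 3, in the downward direction, is therefore expected, written as a 6.9-fold lower number from compound 3 to compound 4 (0.84 log units; beyond the scatter). The number for compound 4 in this assay is estimated at 80 nM, with a likely range from 20 nM to 320 nM.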

Compound 4, inhibition constant: 83 nM
For compound 4 the middle estimate is 1.0-fold (0.02 log units) below the measured one; measured number inside the range.
By their numbers in this assay, from the lowest: compound 2; then compounds 1 and 4 (each within the scatter of the next); then compound 3.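

In this assay the 3-carbamoylphenyl group on the saturated chain carbon bound to a sulfur gives a 6.7-fold lower number from compound 3 to compound 4 (0.82 log units; beyond the scatter) and so shows that pyridin-3-yl is not the only six-membered aromatic ring at this place to go with a lower number than 1H-pyrazol-5-yl. The comparison with the pyridin-3-yl compound gives a 1.2-fold higher number from compound 1 to compound 4 (0.09 log units; within the scatter) and lies within the scatter, so these two groups cannot be told apart at this place, even though the group in compound 4 is a ring of carbon only and carries a carbamoyl group. Nothing available accounts for the difference between either six-membered ring and 1H-pyrazol-5-yl at this place.

The compounds shown leave open whether a plain phenyl ring, or a carboxylic acid in place of the carbamoyl group, would stay level with compound 1 and compound 4. They also leave open whether the 3-carbamoylphenyl group would give a similar number with methyl in place of cyclopropyl on the saturated chain carbon bound to an oxygen on an aromatic ring, the change that separates compound 3 from compound 2.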